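Removing the terminal hydroxy from the sulfonamide chain of compound 3

A few compounds are considered here, and "the series" means these few. Any claim that something is new, unique, unknown or untested is made for them only; others in the source may bear on it.

Measured compounds in a functional assay on K562 cells (Homo sapiens) for antiproliferative activity, read by CCK-8 assay, with a stated time of 72 h; on this read-out lower numbers stand for stronger inhibition of growth and higher numbers for weaker inhibition of growth:
- compound 1, `CCCNS(=O)(=O)c1ccc(Nc2ncc3c(n2)N(C2CCCC2)[C@H](CC)C(=O)N3C)cc1`: 548 nM
- compound 2, `CC[C@@H]1C(=O)N(C)c2cnc(Nc3ccc(S(=O)(=O)NC4CCCC4)cc3)nc2N1C1CCCC1`: 872 nM
- compound 3, `CCC1C(=O)N(C)c2cnc(Nc3ccc(S(=O)(=O)NCCCO)cc3)nc2N1c1ccn(C)n1`: 13400 nM

Compound 3 stands highest of the three numbers in this assay; its nearest neighbour is compound 2 and its furthest is compound 1, both gaps beyond the scatter. Compound 3 also differs from compound 1 and compound 2 in two places at once, so the numbers give no single cause for its standing.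

Compound 4, `CCCNS(=O)(=O)c1ccc(Nc2ncc3c(n2)N(c2ccn(C)n2)C(CC)C(=O)N3C)cc1`, is to be measured. It differs from compound 3 in one place: hydrogen in place of hydroxy on a saturated chain carbon, three bonds along the chain from a sulfonamide nitrogen.

Among the compounds with values here, no measured step concerns this change. Within the data shown here, the only step on record, a 1.6-fold higher number from compound 1 to compound 2 (0.20 log units; within the scatter), alters a different substituent on the sulfonamide nitrogen and lies within the scatter. That step suggests that this end of the molecule tolerates variation without a large shift in the number, but it does not test loss of a hydroxy. On this basis no step beyond the scatter is expected, with a slight lean toward a lower number. Compound 4 is therefore estimated at 9000 nM, within 3000 nM to 27000 nM, meaning an expected step of a 1.5-fold lower number from compound 3 to compound 4 (0.17 log units; within the scatter).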

Compound 4, concentration for 50% growth inhibition: 2260 nM
Estimate against measurement, compound 4: 4.0-fold (0.60 log units) above; the measured number lies below the stated range.
By their numbers in this assay, from the lowest: compounds 1 and 2 (each within the scatter of the next); then compound 4; then compound 3.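

In this assay, within the data shown here, the change of 3-hydroxypropyl to propyl gives the first step at the sulfonamide end of the series that lies beyond the scatter, a 5.9-fold lower number from compound 3 to compound 4 (0.77 log units; beyond the scatter), so the hydroxy on this chain carbon is not a silent feature of compound 3. Among these compounds, the only earlier step at this end, a 1.6-fold higher number from compound 1 to compound 2 (0.20 log units; within the scatter), replaced propyl with cyclopentyl on the sulfonamide nitrogen and showed tolerance for that swap only; it gave no reading on a hydroxy, and the new step shows that such tolerance does not extend to every change at this end. Nothing on record gives a cause for the new step, so it stands here only as an observed difference in the number.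

Still open, on these data alone, is whether a terminal amine or a carboxylic acid on the same chain would give a number nearer compound 3 or compound 4, and whether a longer chain or 2-hydroxyethyl in place of 3-hydroxypropyl would shift it further. Also open, as far as these compounds go, is whether the same hydroxy-to-hydrogen change gives a step of similar size on the core of compound 1, since it is read here on a single pair.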